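The source may hold more compounds than are shown below. What is called first, only, known or untested is meant among the compounds shown, and "the series" means these compounds.

Measured in a functional assay on K562 cells (Homo sapiens) for antiproliferative activity, with a stated time of 72 h; on this read-out higher numbers stand for weaker inhibition and lower numbers for stronger inhibition:
Compound 1 `Nc1ncnn2c([C@@H]3O[C@H](CO)[C@@H](O)[C@H]3O)cc(C#Cc3ccccc3)c12` gives > 100000 nM, a limit of the assay rather than a number.
Compound 2 `Nc1ncnn2c([C@@H]3O[C@H](CO)[C@@H](O)[C@H]3O)cc(-c3ccccc3)c12` gives > 100000 nM, likewise a limit of the assay.

The account follows the step from compound 1 to compound 3 `Nc1ncnn2c([C@@H]3O[C@H](CO)[C@@H](O)[C@H]3O)cc(-c3ccccc3Cl)c12`, which is still unmeasured in this assay. Compound 1 stands only at a limit on the numbers shown; the one further value shown is a limit as well, so neither compound is placed anywhere within the measurable range. The change is 2-chlorophenyl in place of 2-phenylethynyl on an aromatic carbon. Among the compounds with values here, the only measured step that touches the same aromatic carbon is a step that the two limits leave unreadable from compound 1 to compound 2; because both of its ends sit at the limit of > 100000 nM in this assay, at which 2 of the 2 values shown sit, it gives no readable size and no direction. The expectation for compound 3 therefore rests on no measured gradient at all. The nearest comparison is compound 2, which also carries a phenyl on that aromatic carbon of the shared core and stays at the limit. Compound 3 is expected to stay at the limit as well, so its estimated step that the limit leaves unreadable from compound 1 to compound 3 is taken as none beyond the scatter. The estimate for compound 3 is 150000 nM, with a range from 30000 nM to 1000000 nM, and the assay will most likely again report only a limit.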

Compound 3, half-maximal inhibitory concentration: > 100000 nM
Compound 3: only a limit was reported; the forecaster's own chance of this, stated with the estimate: 85%; the middle value does not contradict the limit.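

In this assay compound 3 gives > 100000 nM, a limit of the assay and not a number. The steps among compound 1, compound 2 and compound 3 cannot be read, because all three sit at the same limit: the limit of > 100000 nM in this assay, at which 3 of the 3 values shown sit.

The compounds shown leave open whether any group on that aromatic carbon of the shared core gives a measurable value.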